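The source may report more compounds than this note shows. Statements on the series, on what has been measured and on what is new or still open speak of the compounds shown alone.

In a functional assay on HUVEC cells (Homo sapiens), read by scintillation counting and thymidine incorporation, with a stated time of 24 h (a lower number here means a stronger inhibitor, a higher number a weaker inhibitor), compounds sharing one core have been measured: compound 1 `CCC(C)n1ncn(-c2ccc(N3CCN(c4ccc(OC[C@@H]5CO[C@@](CBr)(c6ccc(Cl)cc6Cl)O5)cc4)CC3)cc2)c1=O` gives 569 nM, compound 2 `CCC(C)n1ncn(-c2ccc(N3CCN(c4ccc(OC[C@@H]5CO[C@@](Cc6ccccc6)(c6ccc(Cl)cc6Cl)O5)cc4)CC3)cc2)c1=O` gives 513 nM, and compound 3 `CCC(C)n1ncn(-c2ccc(N3CCN(c4ccc(OC[C@@H]5CO[C@@](Cn6cnc(C)c6)(c6ccc(Cl)cc6Cl)O5)cc4)CC3)cc2)c1=O` gives 102 nM, the lowest number of the three. Compound 4 `CCC(C)n1ncn(-c2ccc(N3CCN(c4ccc(OC[C@@H]5CO[C@@](Cn6cnnn6)(c6ccc(Cl)cc6Cl)O5)cc4)CC3)cc2)c1=O` has 1H-tetrazol-1-yl in place of 4-methyl-1H-imidazol-1-yl on a saturated chain carbon bound to a saturated ring carbon. The same place was changed in the measured steps: a 1.1-fold lower number from compound 1 to compound 2 (0.04 log units; within the scatter) stayed within the scatter, while a 5.6-fold lower number from compound 1 to compound 3 (0.75 log units; beyond the scatter) and a 5.0-fold lower number from compound 2 to compound 3 (0.70 log units; beyond the scatter) were modest. Within the data shown here, no measured step swaps one such five-membered ring for another, so a modest rise in this assay is expected, smaller than those two steps. The expected step is a 2.5-fold higher number from compound 3 to compound 4 (0.39 log units; beyond the scatter). Compound 4 is estimated at 250 nM, within a range of 90 nM to 700 nM.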

Compound 4, half-maximal inhibitory concentration: 73 nM
Compound 4: middle estimate off by 3.4-fold (0.53 log units), on the high side; the whole stated range lies above it.
By their numbers in this assay, from the lowest: compounds 4 and 3 (each within the scatter of the next); then compounds 2 and 1 (each within the scatter of the next).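

In this assay, replacing one five-membered aromatic ring with another gives a 1.4-fold lower number from compound 3 to compound 4 (0.15 log units; within the scatter), so 1H-tetrazol-1-yl, with four ring hetero atoms, holds the level of 4-methyl-1H-imidazol-1-yl, with two, and the methyl group is not required at this place. Phenyl and bromo remain clearly behind, with a 7.0-fold lower number from compound 2 to compound 4 (0.85 log units; beyond the scatter) and a 7.8-fold lower number from compound 1 to compound 4 (0.89 log units; beyond the scatter), so the advantage seen for compound 3 also appears with a second nitrogen-containing ring. No measurement available here explains these results.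

From the compounds shown here alone, how an amine or a carboxylic acid on this saturated chain carbon would compare remains open. So does the effect of a longer chain carrying the 1H-tetrazol-1-yl ring.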